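This account rests on a few compounds, and the source may have more. Where it says the series, first, only, none or still open, it means among the compounds named here.

Measured so far in a functional assay on CHO-K1 cells for antagonist activity at adenosine receptor A1 (Homo sapiens), read by a beta-galactosidase reporter and cAMP accumulation, with stated times of 15 min and 6 h; a lower number here means a stronger inhibitor, a higher number a weaker inhibitor:
- compound 1, `Cc1csc(-c2nc(N)c3cc(Cc4ccccc4)sc3n2)n1`: 1490 nM
- compound 2, `COc1cccc(-c2nc(N)c3cc(Cc4ccccc4)sc3n2)c1`: 266 nM
- compound 3, `N#Cc1cccc(-c2nc(N)c3cc(Cc4ccccc4)sc3n2)n1`: > 1000 nM, a limit of the assay rather than a number

Compound 3 sits at the limit of > 1000 nM in this assay, at which 1 of the 3 values shown sits; it has no exact number. Compound 2 gives the lowest number of the three, and the step of an at least 3.7-fold higher number from compound 2 to compound 3 (0.57 log units; beyond the scatter) is beyond the scatter. The step of a 5.6-fold lower number from compound 1 to compound 2 (0.75 log units; beyond the scatter) is also beyond the scatter, whereas the step that the limit leaves unreadable from compound 1 to compound 3 cannot be sized.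

Compound 4, `Nc1nc(-c2cccc(Cl)n2)nc2sc(Cc3ccccc3)cc12`, is not yet measured. It differs from compound 3 by chloro in place of cyano on an aromatic carbon. Among the compounds with values here, none of the measured steps changes a substituent on the pyridine: each swaps the whole aromatic group attached to the shared core. They therefore give no direct read on the size of this step in this assay. On the numbers available, compound 4 is expected to stay a weak inhibitor, near the limit where compound 3 sits, with an estimate of 1500 nM and a range from 500 nM to 5000 nM. This estimate corresponds to a step that the limit leaves unreadable from compound 3 to compound 4, and a measurement may again report only a limit.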

Compound 4, inhibition constant: > 1000 nM
Compound 4: only a limit was reported; the forecaster's own chance of this, stated with the estimate: 45%; the middle value lies beyond the limit too.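

In this assay compound 4 gives > 1000 nM, which is a limit of the assay and not a number. The change from 3-methoxyphenyl to 6-chloropyridin-2-yl gives an at least 3.7-fold higher number from compound 2 to compound 4 (0.57 log units; beyond the scatter), so a pyridine carrying chloro, like the one carrying cyano, stays apart from the 3-methoxyphenyl group of compound 2. The steps to compound 4 from compound 3 and from compound 1 cannot be read, because limits stand on them: the limit of > 1000 nM in this assay, at which 2 of the 4 values shown sit.

From the compounds shown here alone, whether chloro and cyano differ at all at this place next to the ring nitrogen remains open. Also open, going by these compounds, is whether an amine or a carboxylic acid at the same place would give a measurable number in this assay, and whether any such pyridine could come close to compound 2 at 266 nM.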